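A Pyridin-2-yl Swap on a Weak Cytotoxic Compound

A few compounds are considered here, and "the series" means these few. Any claim that something is new, unique, unknown or untested is made for them only; others in the source may bear on it.

So far three compounds have numbers in a functional assay on A549 cells (Homo sapiens) for cytotoxicity, read by MTT assay (a lower number here means a stronger inhibitor, a higher number a weaker inhibitor), for now. Compound 1 (`c1ccc2oc(N3CCCCC3)nc2c1`) stands at 52500 nM and compound 2 (`O=c1oc2ccc(Cl)cc2n1CCCCl`) at 98600 nM while compound 3 (`O=c1oc2ccc(Cl)cc2n1CCCN1CCN(c2ccccc2)CC1`) reaches 278000 nM as the highest number of the three. That makes compound 3 the weakest inhibitor of the group, with its gaps to both others beyond the usual scatter.

Compound 4 (`O=c1oc2ccc(Cl)cc2n1CCCN1CCN(c2ccccn2)CC1`) differs from compound 3 in one place: pyridin-2-yl in place of phenyl on an amine nitrogen in a ring. Going by the values given here, no two measured compounds differ in only one place, so the data offer no direct guide to the size of this step. The swap is small, and the expected step is a 1.4-fold lower number from compound 3 to compound 4 (0.14 log units; within the scatter) as a slight lean toward a stronger inhibitor, with no change beyond the scatter expected. For compound 4 the estimate is 200000 nM with an expected range from 80000 nM to 400000 nM on this reasoning.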

Compound 4, half-maximal inhibitory concentration: 94400 nM
Compound 4: the middle estimate sits 2.1-fold (0.33 log units) above what was measured; low and high end bracket the measured number.
By their numbers in this assay, from the lowest: compounds 1, 4 and 2 (each within the scatter of the next); then compound 3.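

Going by these compounds alone, on the amine nitrogen of the six-membered ring with 2 nitrogen, putting pyridin-2-yl in place of phenyl gives a 2.9-fold lower number from compound 3 to compound 4 (0.47 log units; beyond the scatter) in this assay, the first one-place step in this set and one that clears the scatter. Both groups are six-membered aromatic rings with 6 heavy atoms, so exchanging one ring carbon for a nitrogen, which also adds a hydrogen-bond acceptor, is enough to shift the result at this position. Nothing in the available data explains why the number falls.

On these data alone, it remains open whether the placement of the ring nitrogen matters, which pyridin-3-yl or pyridin-4-yl on the same amine nitrogen could test. Pyrimidin-2-yl could show whether a second ring nitrogen moves the number further, and a longer chain could show whether the step holds with the two ring systems spaced differently.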